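Sulfonamide aryl swaps on the benzoxazole series

This account rests on a few compounds, and the source may have more. Where it says the series, first, only, none or still open, it means among the compounds named here.

Compound 3, `COc1ccc(Cl)cc1S(=O)(=O)Nc1ccc(-c2nc3ccccc3o2)cc1`, stands only at a limit of an assay on isolated protein for inhibition of malate dehydrogenase, mitochondrial (Sus scrofa), with stated times of 45 min and 30 min; a higher number here means a weaker inhibitor, a lower number a stronger inhibitor: in this assay compound 3 gives > 63000 nM, which is a limit of the assay and not a number. Compound 1, `O=S(=O)(Nc1ccc(-c2nc3ccccc3o2)cc1)c1cccs1`, gives > 63000 nM in this assay, likewise a limit. Compound 2, `COc1ccc(S(=O)(=O)Nc2ccc(-c3nc4ccccc4o3)cc2)cc1`, gives > 63000 nM in this assay, again a limit. Among the compounds with values here, all three values sit at the same point, as the limit of > 63000 nM in this assay, at which 3 of the 3 values shown sit, records, so none of the measured steps can be read: a step that the two limits leave unreadable from compound 1 to compound 2, a step that the two limits leave unreadable from compound 1 to compound 3 and a step that the two limits leave unreadable from compound 2 to compound 3 are all of unreadable size.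

Compound 4, `CCc1ccc(S(=O)(=O)Nc2ccc(-c3nc4ccccc4o3)cc2)cc1`, differs from compound 3 at the sulfonyl sulfur: 4-ethylphenyl in place of 5-chloro-2-methoxyphenyl on a sulfonyl sulfur. The measured steps that bear on this change, the aryl swaps from compound 1 to compound 2, from compound 1 to compound 3 and from compound 2 to compound 3, give no readable size in this assay, so no step beyond the scatter is expected. The estimate for compound 4 is therefore a value at or past the limit, 100000 nM (range 30000 nM to 400000 nM), an expected step that the limit leaves unreadable from compound 3 to compound 4.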

Compound 4, half-maximal inhibitory concentration: > 63000 nM
Compound 4 ended at the assay's limit (the forecaster's own chance of this, stated with the estimate: 85%); the middle value does not contradict the limit.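

Compound 4 stays at a limit in this assay, like compound 1, compound 2 and compound 3, so none of the steps to compound 4 can be read: the limit of > 63000 nM in this assay, at which 4 of the 4 values shown sit.

The compounds shown leave open whether any group on the sulfonyl sulfur of the shared core gives a measurable value in this assay.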